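A methyl step repeated across two cores

The source may hold more compounds than are shown below. What is called first, only, known or untested is meant among the compounds shown, and "the series" means these compounds.

Measured compounds:
compound 1 `CCC(C)C1NC(=O)N(C2CCCCC2)C1=O`, 94300 nM
compound 2 `CC(C)C(NC(=O)n1nnc2ccccc21)C(=O)NC1CCCC1`, 79300 nM
compound 3 `CC(C)C1NC(=O)N(C2CCCCC2)C1=O`, > 100000 nM

Working notes. In a functional assay on MCF7 cells (Homo sapiens) for inhibition (a lower number here means a stronger inhibitor, a higher number a weaker inhibitor), compound 1 gives 94300 nM. In this assay compound 2 gives 79300 nM. For compound 3 the result in this assay is only a limit, > 100000 nM, and no number is known for it. Compound 2 has the lowest of the two numbers, but its nearest neighbour is compound 1 and the two lie within the scatter of each other, so no order between them is claimed. One of the three results sits at the limit of > 100000 nM in this assay, at which 1 of the 3 values shown sits.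

Within the data shown here, the one change seen twice across the series is methyl in place of hydrogen on a saturated chain carbon, two bonds along the chain from a saturated ring carbon. From the core of compound 3 to compound 1 this gives an at least 1.0-fold lower number from compound 3 to compound 1 (0.02 log units; that floor lies within the scatter); as compound 3 is a limit, only a floor for that step is known, and that floor is within the scatter.

The unmeasured compound is compound 4 `CCC(C)C(NC(=O)n1nnc2ccccc21)C(=O)NC1CCCC1`. It arises from compound 2 by methyl in place of hydrogen on a saturated chain carbon, three bonds along the chain from an amide-type nitrogen and a carbonyl carbon. This is the same kind of change as from compound 3 to compound 1, but the surroundings differ: in compound 1 the methyl sits on a saturated chain carbon two bonds along the chain from a saturated ring carbon, while in compound 4 it sits on a saturated chain carbon three bonds along the chain from an amide-type nitrogen and a carbonyl carbon. How the core of compound 2 differs from that of compound 3 is not broken down here.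

Resting on the step from compound 3 to compound 1, an at least 1.0-fold lower number from compound 3 to compound 1 (0.02 log units; that floor lies within the scatter), which gives only a floor within the scatter, the expected step from compound 2 to compound 4 in this assay is small, a 1.2-fold lower number from compound 2 to compound 4 (0.09 log units; within the scatter). Compound 4 is therefore estimated at 65000 nM in this assay, with a range from 20000 nM to 200000 nM, and a real chance that only a limit is reported.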

Compound 4, half-maximal inhibitory concentration: 63700 nM
Compound 4: the middle estimate sits 1.0-fold (0.01 log units) above what was measured, and the stated range covers the measured number.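

In this assay, methyl in place of hydrogen on the core of compound 2, which turns isopropyl into sec-butyl, gives a 1.2-fold lower number from compound 2 to compound 4 (0.10 log units; within the scatter). Set beside the same change on the core of compound 3, the two steps read: the same change on two cores in this assay, an at least 1.0-fold lower number (0.02 log units; that floor lies within the scatter) from compound 3 to compound 1 and a 1.2-fold lower number (0.10 log units; within the scatter) from compound 2 to compound 4; the limit leaves it open whether they differ For compound 3 the result of > 100000 nM is a limit and not a number, so the step on that core has only a floor; the series therefore shows neither that the change carries from one core to the other with the same size nor that its size differs between them.

The compounds shown carry only isopropyl or sec-butyl at this place, which leaves open what a longer chain, an amine or a carboxylic acid there would do in this assay, and whether any change at this place gives a step beyond the scatter. Reading such steps on the core of compound 3 also stays limited by how close the values lie to the top of the measured range, and one result already sits there: the limit of > 100000 nM in this assay, at which 1 of the 4 values shown sits.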